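A few compounds are considered here, and "the series" means these few. Any claim that something is new, unique, unknown or untested is made for them only; others in the source may bear on it.

Of the compounds shown here, three of a shared core have been measured in an assay on HEK293 cells for displacement of a labelled ligand from 5-hydroxytryptamine receptor 6 (Homo sapiens), read by scintillation counting; a lower number here means a stronger inhibitor, a higher number a weaker inhibitor. Compound 1 `O=S(=O)(c1ccc2cccnc2c1)n1cc(C2=CCNCC2)c2ccccc21` gives 7 nM. Compound 2 `COc1ccc2c(c1)c(C1CCNCC1)cn2S(=O)(=O)c1ccc2cccnc2c1` gives 30 nM, the largest of the three numbers, and compound 3 `COc1ccc2c(c1)c(C1CCNCC1)cn2S(=O)(=O)c1cncc2ccccc12` gives 24 nM. The gap from compound 2 to compound 1 lies beyond the scatter, whereas the change a 1.3-fold lower number from compound 2 to compound 3 (0.10 log units; within the scatter) does not, so those two are not separated.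

Compound 4 `CCCCN1CC=C(c2cn(S(=O)(=O)c3ccc4cccnc4c3)c3ccc(OC)cc23)CC1` is derived from compound 2 by the change (a group of 10 heavy atoms (9 carbon, 1 nitrogen; one six-membered non-aromatic ring with 1 hetero atom) in place of a group of 6 heavy atoms (5 carbon, 1 nitrogen; one six-membered non-aromatic ring with 1 hetero atom), on an aromatic carbon). Within the data shown here, compound 1 and compound 2 differ in two places at once, so their gap cannot be assigned to either change, and no measured step touches the swap of the nitrogen-bearing ring itself. The closest single step, a 1.3-fold lower number from compound 2 to compound 3 (0.10 log units; within the scatter), concerns the sulfonyl substituent and says nothing about this position. Among the measured compounds shown here, with no direct precedent, the expectation for compound 4 is a moderately higher number than compound 2, the step being estimated as a 3.3-fold higher number from compound 2 to compound 4 (0.52 log units; beyond the scatter). Compound 4 is therefore expected to give about 100 nM in this assay, with a range from 25 nM to 500 nM.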

Compound 4, inhibition constant: 219 nM
For compound 4 the middle estimate is 2.2-fold (0.34 log units) below the measured one; the range from low to high includes it.
By their numbers in this assay, from the lowest: compound 1; then compounds 3 and 2 (each within the scatter of the next); then compound 4.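

In this assay this position proves sensitive to substitution, with a 7.3-fold higher number from compound 2 to compound 4 (0.86 log units; beyond the scatter), the first step among the compounds shown that can be assigned to one place and lies beyond the scatter. That one swap carries several differences at once: piperidin-4-yl has 1 hydrogen-bond donor and 6 heavy atoms, while the entering group has 0 hydrogen-bond donors, 10 heavy atoms and 1 double bond outside aromatic rings, so the step belongs to the group as a whole. Nothing measured here offers an explanation for this step.

The compounds shown leave open how the step divides between the butyl chain and the double bond. A piperidin-4-yl bearing a butyl chain, or the same unsaturated ring bearing a methyl group in place of butyl, would begin to separate the two.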